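The source may report more compounds than this note shows. Statements on the series, on what has been measured and on what is new or still open speak of the compounds shown alone.

Two compounds share one core and differ only in a single group on the outer six-membered ring. Compound 1 `O=S(=O)(Nc1nnc(SCc2ccccc2)s1)c1ccccc1` carries hydrogen there, and in a toxicity assay on HaCaT cells (Homo sapiens) for cytotoxicity, tested at 250 uM (a lower number here means a stronger effect, a higher number a weaker effect of the compound at the concentration tested), compound 1 gives 68%. Compound 2 `Cc1ccc(S(=O)(=O)Nc2nnc(SCc3ccccc3)s2)cc1` carries methyl in that place, and in this assay compound 2 gives 65%. Compound 2 thus stands close to compound 1, and the two numbers cannot be told apart. Compound 3 `COc1ccc(S(=O)(=O)Nc2nnc(SCc3ccccc3)s2)cc1` has not yet been measured; it differs from compound 2 by methoxy in place of methyl on an aromatic carbon. Going by the values given here, only one measured step bears on this change, namely a number 3 percentage points lower from compound 1 to compound 2 (within the scatter), which stayed within the scatter. A further change of the same kind at the same place is therefore expected to move the read-out little, if at all. For compound 3 in this assay a value of 65% is expected, between 50% and 80%, so that the expected step is no change at the digits printed from compound 2 to compound 3 (within the scatter).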

Compound 3, a percentage reported as activity, at one concentration (the size of the read-out at that concentration, not a potency): 57%
Beside the measured number, compound 3's estimate is 8 percentage points above it, and the stated range covers the measured number.
By their numbers in this assay, from the lowest: compounds 3, 2 and 1 (each within the scatter of the next, the first and the last beyond it).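

Swapping methyl for methoxy at this position, para to a large group, gives in this assay a number 8 percentage points lower from compound 2 to compound 3 (within the scatter), so this step alone cannot be told apart from ordinary variation between repeated measurements. Going by these compounds alone, measured against the unsubstituted ring, however, methoxy gives a number 11 percentage points lower from compound 1 to compound 3 (beyond the scatter), the first step at this position to pass the scatter, and it points to a modestly stronger effect at the tested concentration, whereas methyl in place of hydrogen did not pass it. Nothing available explains this difference between the two groups.

The compounds shown leave open whether a chlorine atom, an amine or a carboxylic acid at this place would give a step of similar size. They also leave open whether methoxy would act the same way elsewhere on the ring.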